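This account rests on a few compounds, and the source may have more. Where it says the series, first, only, none or still open, it means among the compounds named here.

Of the compounds shown here, three have been measured in a functional assay on A549 cells (Homo sapiens) for antiproliferative activity, read by MTT assay, with a stated time of 72 h; a higher number here means a weaker inhibitor, a lower number a stronger inhibitor. Compound 1 `CC(Oc1ncnc2ccc(-c3cnn(C4CCNCC4)c3)cc12)c1c(Cl)ccc(F)c1Cl` gives 6750 nM. Compound 3 `CC(Oc1ncnc2ccc(-c3cnn(C)c3)cc12)c1c(Cl)ccc(F)c1Cl` differs from compound 1 in one place: methyl in place of piperidin-4-yl on an aromatic nitrogen The step of a 4.3-fold higher number from compound 1 to compound 3 (0.63 log units; beyond the scatter) shows that trading the piperidin-4-yl for a methyl on that aromatic nitrogen weakens the compound by a modest amount. Compound 2 `c1cnc2ccc(Nc3ncnc4ccc(-c5cnn(C6CCNCC6)c5)cc34)cc2c1` keeps the piperidin-4-yl on the aromatic nitrogen but carries a different core; the difference between the two cores is not broken down here. In this assay compound 2 gives 32000 nM, the highest of the three numbers, while compound 3 gives 28800 nM, a number that lies within the scatter of that of compound 2.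

Compound 4 `Cn1cc(-c2ccc3ncnc(Nc4ccc5ncccc5c4)c3c2)cn1` has not yet been measured. It stands to compound 2 as compound 3 stands to compound 1: methyl in place of piperidin-4-yl on an aromatic nitrogen The place of the change is described in the same words in both pairs, so this is the same change made on a different core. Because the same change produced a 4.3-fold higher number from compound 1 to compound 3 (0.63 log units; beyond the scatter), a step of similar size is expected here, a 2.8-fold higher number from compound 2 to compound 4 (0.45 log units; beyond the scatter). Compound 4 is accordingly estimated at 90000 nM, with a likely range from 35000 nM to 250000 nM. Since compound 2 already sits high, the measurement of compound 4 may well reach the edge of what this assay reports.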

Compound 4, half-maximal inhibitory concentration: 1380 nM
Beside the measured number, compound 4's estimate is 65-fold (1.81 log units) above it; the measured number lies below the stated range.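

In this assay, putting methyl in place of piperidin-4-yl on the aromatic nitrogen gives a 23-fold lower number from compound 2 to compound 4 (1.37 log units; beyond the scatter), so the change that weakened the compound on one core strengthens it on the other. The result of this change therefore does not carry from one core to the other, in either direction or size: the same change on two cores in this assay, a 4.3-fold higher number (0.63 log units; beyond the scatter) from compound 1 to compound 3 and a 23-fold lower number (1.37 log units; beyond the scatter) from compound 2 to compound 4, 99-fold (2.00 log units) apart, beyond the scatter of two such steps. Among the compounds shown here, this shows that, in this series, a step measured on one core cannot simply be added to a compound with another core, but it rests on only two pairs of compounds and does not show which feature of the cores sets the outcome, nor why the direction reverses.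

As far as these compounds go, it remains open how an ethyl group, a longer chain or a short chain ending in an amine would behave on that aromatic nitrogen on each core, and whether such compounds would follow the pair of compound 1 and compound 3 or the pair of compound 2 and compound 4. From the compounds shown here alone, it also remains open which of the differences between the two cores matters, a question that could only be answered by compounds changing those parts one at a time.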